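A few compounds are considered here, and "the series" means these few. Any claim that something is new, unique, unknown or untested is made for them only; others in the source may bear on it.

Working notes on the series.

Of the compounds shown here, three of the shared core have been measured in an assay on membranes from HEK293 cells for displacement of a labelled ligand from Translocator protein (Homo sapiens), read by scintillation counting, with a stated time of 90 min; on this read-out higher numbers stand for weaker inhibition and lower numbers for stronger inhibition. Compound 1 `CCN(CC)C(=O)c1nc2ccccc2n1Cc1ccc(Cl)cc1` gives > 10000 nM, which is a limit of this assay and not a number. Compound 2 `CN(Cc1ccccc1)C(=O)c1nc2ccccc2n1Cc1ccc(Cl)cc1` likewise gives > 10000 nM, again a limit rather than a number. Within the data shown here, compound 3 `C#CCN(C)C(=O)c1nc2ccccc2n1Cc1ccc(OC)cc1` gives 3280 nM, the only actual number in the set so far. The step from compound 1 to compound 2, a step that the two limits leave unreadable from compound 1 to compound 2, cannot be read because the limit of > 10000 nM in this assay, at which 2 of the 3 values shown sit, covers both ends of it.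

The unmeasured compound 4 `C#CCN(C)C(=O)c1nc2ccccc2n1Cc1ccc(Cl)cc1` differs from compound 3 in one place: chloro in place of methoxy on an aromatic carbon. Among the measured compounds shown here, no measured step in the set changes this position, so there is no direct guide to its size. For the measured compounds named here, compounds 1 and 2 carry the same chloro group but with different amide substituents, and both sit at the limit; compound 3 with methoxy gives the one real number. On that basis the step is expected to be small to moderate, with weaker binding somewhat more likely than stronger, and with a fair chance that only a limit is reported. Compound 4 is therefore estimated at 5000 nM, with a range from 1500 nM to 15000 nM, corresponding to an expected step of a 1.5-fold higher number from compound 3 to compound 4 (0.18 log units; within the scatter).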

Compound 4, inhibition constant: > 10000 nM
Compound 4 gave a limit, no number; the forecaster's own chance of this, stated with the estimate: 30%; at least 2.0-fold (0.30 log units) between middle value and limit.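

At this position, on an aromatic carbon of a six-membered aromatic ring of carbon only, para to a large group, the series now has its first readable step: with the rest of compound 3 held constant in this assay, chloro in place of methoxy gives an at least 3.0-fold higher number from compound 3 to compound 4 (0.48 log units; beyond the scatter). This size is a lower bound only: compound 4 stands at a limit of the assay, not at a number. The steps to compound 4 from compound 1 and from compound 2 cannot be read, because both ends of each lie at the same limit: the limit of > 10000 nM in this assay, at which 3 of the 4 values shown sit.

The compounds shown give no other group at this position, so it remains open whether a hydroxy, a methyl or a fluoro group would stay close to methoxy or fall to the limit with chloro. Also open is whether the 4-methoxyphenyl group would give a measurable number with diethylamino or benzyl(methyl)amino on the carbonyl carbon, where only the 4-chlorophenyl group is shown.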